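Swapping Thiophene for Cyclohexyl on the Amide Carbonyl

The compounds below may be only part of what the source reports. "The series", "measured", "known", "first", "only" and "open" are said of these compounds alone.

Measured so far, in a functional assay on HeLa cells (Homo sapiens) for antiproliferative activity, read by MTT assay, with a stated time of 48 h; on this read-out higher numbers stand for weaker inhibition and lower numbers for stronger inhibition:
compound 1 `COc1ccc(-c2cn3cc(C4=CCN(S(=O)(=O)CCc5ccccc5)CC4)ccc3n2)cc1OC` gives 8980 nM
compound 2 `COc1ccc(-c2cn3cc(C4=CCN(C(=O)c5cccs5)CC4)ccc3n2)cc1OC` gives 16000 nM

Only these two compounds have been measured, and the step of a 1.8-fold higher number from compound 1 to compound 2 (0.25 log units; within the scatter) leaves compound 2 within the scatter of compound 1. Compound 3 `COc1ccc(-c2cn3cc(C4=CCN(C(=O)C5CCCCC5)CC4)ccc3n2)cc1OC` differs from compound 2 in one place: cyclohexyl in place of thiophen-2-yl on a carbonyl carbon. Among the measured compounds shown here, the single measured step, a 1.8-fold higher number from compound 1 to compound 2 (0.25 log units; within the scatter), exchanged the whole group on the ring nitrogen and was itself within the scatter, so it gives no direction for exchanging only the ring on the carbonyl carbon. The expected step is therefore none beyond the scatter, a 1.1-fold lower number from compound 2 to compound 3 (0.06 log units; within the scatter). Compound 3 is estimated at 14000 nM, between 5000 nM and 40000 nM.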

Compound 3, half-maximal inhibitory concentration: 8060 nM
Compound 3: middle estimate off by 1.7-fold (0.24 log units), on the high side, and the stated range covers the measured number.
By their numbers in this assay, from the lowest: compounds 3, 1 and 2 (each within the scatter of the next).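

In this assay, a non-aromatic carbon ring on the carbonyl carbon reads the same as an aromatic sulfur-containing one, with cyclohexyl in place of thiophen-2-yl giving (a 2.0-fold lower number from compound 2 to compound 3 (0.30 log units; within the scatter)). On the ring nitrogen, cyclohexylcarbonyl in place of phenethylsulfonyl gives (a 1.1-fold lower number from compound 1 to compound 3 (0.05 log units; within the scatter)), so none of the three groups shown separates from the others at this position. No supporting measurement is available to explain these numbers. Still open, as far as these compounds go, is whether an amine or a carboxylic acid on the carbonyl side, or a longer chain there, would move the number beyond the scatter.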